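Compound 4: Replacing Thiophen-3-yl with 2-Fluoropyridin-3-yl

The source may hold more compounds than are shown below. What is called first, only, known or untested is meant among the compounds shown, and "the series" means these compounds.

Of the compounds shown here, three have been tested so far in a functional assay on KYSE-70 cells for antiproliferative activity against KYSE-70 cell line (Homo sapiens), read by MTT assay, with a stated time of 72 h; on this read-out lower numbers stand for stronger inhibition and higher numbers for weaker inhibition. Compound 1 `O=C(Nc1ccc(Cl)cc1)c1ccnc2cc(Br)ccc12` reaches only the limit of the measurement: in this assay compound 1 gives > 20000 nM. Compound 2 `O=C(c1cc(=O)[nH]c2cc(Br)ccc12)N1CCCCC1` likewise stops at a limit, as in this assay compound 2 gives > 20000 nM. Among the measured compounds shown here, compound 3 `O=C(Nc1cccc(F)c1)c1cc(=O)[nH]c2cc(-c3ccsc3)ccc12` is the one compound with an actual number: in this assay compound 3 gives 5100 nM. That makes compound 3 the only point of reference. The other two sit at the limit of > 20000 nM in this assay, at which 2 of the 3 values shown sit.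

Compound 4 `O=C(Nc1cccc(F)c1)c1cc(=O)[nH]c2cc(-c3cccnc3F)ccc12` is still to be measured. It differs from compound 3 in one place (2-fluoropyridin-3-yl in place of thiophen-3-yl on an aromatic carbon). No pair of measured compounds differs in exactly one place, so there is no measured step to lean on, and the swap of thiophen-3-yl for 2-fluoropyridin-3-yl has no precedent among these three. The expectation is therefore a step in this assay no larger than the usual scatter, in no firm direction, and the expected step is a 1.0-fold lower number from compound 3 to compound 4 (0.01 log units; within the scatter). For compound 4 the estimate in this assay is 5000 nM, with a range from 1500 nM to 16000 nM.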

Compound 4, half-maximal inhibitory concentration: > 20000 nM
Compound 4: only a limit was reported (the forecaster's own chance of this, stated with the estimate: 20%); at least 4.0-fold (0.60 log units) between middle value and limit.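

Among the compounds shown here, this is the first comparison in the set between compounds that differ in one place, and it shows that the group on this aromatic carbon matters in this assay: 2-fluoropyridin-3-yl in place of thiophen-3-yl gives an at least 3.9-fold higher number from compound 3 to compound 4 (0.59 log units; beyond the scatter). On these data alone, compound 4 gives > 20000 nM, which is a limit and not a number, so the step fixes only the smallest possible size of the change and its true size remains unknown. Compound 3, with thiophen-3-yl, remains the only compound shown with an actual number, while the others stop at the same limit: the limit of > 20000 nM in this assay, at which 3 of the 4 values shown sit.

The change brings in a six-membered ring, a ring nitrogen and a fluorine all at once, and the compounds shown cannot say which of these, if any, accounts for the step. Also open, as far as these compounds go, is whether a plain phenyl ring, a pyridin-3-yl ring without the fluorine, a thiophen-2-yl ring or an amine such as morpholine on this same carbon would give a measurable number in this assay.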